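From amino to nitro among closely spaced values

The source may hold more compounds than are shown below. What is called first, only, known or untested is meant among the compounds shown, and "the series" means these compounds.

- compound 1 `O=C(Cn1cc(CO)nn1)NCc1ccccc1` gives 490 uM
- compound 2 `CCC(O)Cc1cn(CC(=O)NCc2ccccc2)nn1` gives 630 uM
- compound 3 `Nc1cccc(-c2cn(CC(=O)NCc3ccccc3)nn2)c1` gives 800 uM

All three values come from an ADME assay on cells (spleen, Mus musculus, strain C57BL/6) for inhibition, read by flow cytometry and propidium iodide staining, with a stated time of 24 h, at 37 degrees C (on this read-out lower numbers stand for an effect already at smaller amounts and higher numbers for an effect only at larger amounts of compound), and lie close together. Compound 3 stands level with the other two, as the data show a 1.6-fold higher number from compound 1 to compound 3 (0.21 log units; within the scatter) and a 1.3-fold higher number from compound 2 to compound 3 (0.10 log units; within the scatter) and so it cannot be told apart from either. The remaining step, a 1.3-fold higher number from compound 1 to compound 2 (0.11 log units; within the scatter) and no more, is no different in kind.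

Compound 4 `O=C(Cn1cc(-c2cccc([N+](=O)[O-])c2)nn1)NCc1ccccc1` differs from compound 3 in one place, with nitro in place of amino on an aromatic carbon. Among the compounds with values here, no measured step exchanges the amino group on its own, so the evidence is indirect. The two steps that bring in the whole 3-aminophenyl group, a 1.6-fold higher number from compound 1 to compound 3 (0.21 log units; within the scatter) and a 1.3-fold higher number from compound 2 to compound 3 (0.10 log units; within the scatter) in turn, stayed within the scatter. On that basis, no step beyond the scatter is expected in this assay for this change, and no direction can be favoured with confidence. The estimate amounts to a 1.2-fold lower number from compound 3 to compound 4 (0.09 log units; within the scatter) as the expected step. The estimated value for compound 4 is 650 uM with a range of 320 uM to 1300 uM expected.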

Compound 4, concentration for half-maximal effect: > 2000 uM
Compound 4: a limit, no number (the forecaster's own chance of this, stated with the estimate: 10%); at least 3.0-fold (0.48 log units) between middle value and limit.
By their numbers in this assay, from the lowest: compounds 1, 2 and 3 (each within the scatter of the next). At a limit, above all of these: compound 4.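

In this assay, an at least 2.5-fold higher number from compound 3 to compound 4 (0.39 log units; beyond the scatter) is the only step among the compounds shown that lies beyond the scatter, so a change on this aromatic carbon can register in this assay even though the earlier exchanges of the whole group did not. The result also shows that the identity of the small group on the phenyl ring matters here, since nitro and amino on the same aromatic carbon, with the rest of the molecule unchanged, do not read alike. Compound 4 gives only a limit, > 2000 uM, and not a number, so the size of the step has a floor but no ceiling: the limit of > 2000 uM in this assay, at which 1 of the 4 values shown sits.

Heavy atoms, hydrogen-bond donors and hydrogen-bond acceptors all change at once in this swap, and the two compounds alone cannot show which of these differences counts, or whether any of them does. From the compounds shown here alone, it also remains open whether a nitrile, a methoxy group or a carboxylic acid on that same aromatic carbon would read like compound 3 or like compound 4, and how far compound 4 actually lies beyond its limit.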